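Amide aryl exchange on the shared core: chlorophenyl variant

This account rests on a few compounds, and the source may have more. Where it says the series, first, only, none or still open, it means among the compounds named here.

Compound 1 `CN(C)CCNc1cc2c(cn1)cc(NC(=O)c1cc3ccccc3s1)c(=O)n2C` is the reference point of this series. For the measured compounds named here, in a functional assay on MCF7 cells (Homo sapiens) for antiproliferative activity, read by MTT assay, with a stated time of 48 h (on this read-out lower numbers stand for stronger inhibition and higher numbers for weaker inhibition), compound 1 gives 12000 nM, the lowest of the three numbers so far. Compound 3 `COc1cc(C(=O)Nc2cc3cnc(NCCN(C)C)cc3n(C)c2=O)cc(OC)c1OC` gives 21500 nM in this assay, and its gap to compound 1 sits within the scatter. Compound 2 `CN(C)CCNc1cc2c(cn1)cc(NC(=O)c1ccccc1)c(=O)n2C` gives 35100 nM in this assay; the step of a 2.9-fold higher number from compound 1 to compound 2 (0.47 log units; beyond the scatter) lies beyond the scatter and counts as modest.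

Compound 4 `CN(C)CCNc1cc2c(cn1)cc(NC(=O)c1ccc(Cl)cc1)c(=O)n2C` differs from compound 1 in one place: 4-chlorophenyl in place of 1-benzothiophen-2-yl on a carbonyl carbon. Going by the values given here, the only measured step that bears on this exchange is the one from the 1-benzothiophen-2-yl group to a six-membered aromatic ring of carbon only, namely a 2.9-fold higher number from compound 1 to compound 2 (0.47 log units; beyond the scatter). A 4-chlorophenyl group is a closely related replacement, so a step in the same direction, of similar or somewhat smaller size, is expected in this assay. Compound 4 is therefore estimated at 25000 nM, with a range from 10000 nM to 60000 nM. That estimate corresponds to an expected step of a 2.1-fold higher number from compound 1 to compound 4 (0.32 log units; beyond the scatter).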

Compound 4, half-maximal inhibitory concentration: 3090 nM
The estimate for compound 4 lay 8.1-fold (0.91 log units) above the measured number; the measured number lies below the stated range.
By their numbers in this assay, from the lowest: compound 4; then compounds 1, 3 and 2 (each within the scatter of the next, the first and the last beyond it).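

Chloro in place of hydrogen on an aromatic carbon gives an 11-fold lower number from compound 2 to compound 4 (1.06 log units; beyond the scatter) in this assay, so the amide aryl position responds strongly to this single change on the phenyl ring. The 1-benzothiophen-2-yl group is also not needed for a low number here, since 4-chlorophenyl on the same carbonyl carbon gives a 3.9-fold lower number from compound 1 to compound 4 (0.59 log units; beyond the scatter) and reverses the direction seen with the unsubstituted phenyl of compound 2. No data at hand explain either step.

On these data alone, whether this gain is specific to chloro remains open, and a bromo, methyl or nitrile group in its place on the phenyl ring of compound 4 would test that. As far as these compounds go, it is also open whether a chloro on the 1-benzothiophen-2-yl group of compound 1 would lower the number as well.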